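The source may hold more compounds than are shown below. What is called first, only, known or untested is meant among the compounds shown, and "the series" means these compounds.

Three close relatives share one core and differ only in the group carried on the six-membered aromatic ring of carbon only. Compound 1 `Cn1nnnc1SCC(=O)N/N=C/c1ccccc1` carries hydrogen there, and in an ADME assay on NIH3T3 cells (Mus musculus) for cytotoxicity, read by XTT assay, with a stated time of 24 h (on this read-out lower numbers stand for stronger inhibition and higher numbers for weaker inhibition), compound 1 gives 9700000 nM. Compound 2 `Cn1nnnc1SCC(=O)N/N=C/c1ccc([N+](=O)[O-])cc1` carries nitro, and in this assay compound 2 gives 9300000 nM. Compound 3 `Cn1nnnc1SCC(=O)N/N=C/c1ccc(F)cc1` carries fluoro, and in this assay compound 3 gives 10000000 nM. Compound 1 thus stands second highest of the three numbers, with compound 3 nearest and compound 2 furthest; all three lie within the scatter of one another, so no order among them can be read.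

Compound 4 `Cn1nnnc1SCC(=O)N/N=C/c1ccc(Cl)cc1` brings (chloro in place of hydrogen on an aromatic carbon). Among the compounds with values here, two measured steps bear on this change, since each swaps that same hydrogen for another group: a 1.0-fold lower number from compound 1 to compound 2 (0.02 log units; within the scatter) and a 1.0-fold higher number from compound 1 to compound 3 (0.01 log units; within the scatter). Neither moved the number beyond the scatter. A chloro in place of hydrogen is therefore expected to behave alike, giving no change at the digits printed from compound 1 to compound 4 (within the scatter). Compound 4 is accordingly estimated at 9700000 nM, with a likely range from 5500000 nM to 17000000 nM.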

Compound 4, half-maximal inhibitory concentration: 2100000 nM
For compound 4 the middle estimate is 4.6-fold (0.66 log units) above the measured one; the measured number lies below the stated range.
By their numbers in this assay, from the lowest: compound 4; then compounds 2, 1 and 3 (each within the scatter of the next).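

Within the data shown here, at this position the groups turn out not to be interchangeable: in this assay chloro is the first group to move the number beyond the scatter, with a 4.6-fold lower number from compound 1 to compound 4 (0.66 log units; beyond the scatter) and, measured against the other two groups, with a 4.8-fold lower number from compound 3 to compound 4 (0.68 log units; beyond the scatter) and a 4.4-fold lower number from compound 2 to compound 4 (0.65 log units; beyond the scatter) as well. Compound 4 thus has the lowest number of the four, meaning stronger inhibition on this read-out, although these steps are modest, and compounds 2 and 3 go against any idea that replacing this hydrogen always lowers the number. No measurement at hand accounts for why chloro stands apart from fluoro and nitro here.

As far as these compounds go, whether this drop is special to chloro remains open, and a bromo, a methyl or an amine at the same place could test that. Also unsettled is whether chloro would give the same step at another place on the ring.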